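This account rests on a few compounds, and the source may have more. Where it says the series, first, only, none or still open, it means among the compounds named here.

Values so far in an ADME assay on a cell-free system (plasma, Rattus norvegicus) for metabolic stability, read by LC-MS, with a stated time of 1 h, at 37 degrees C, tested at 100 uM; a lower number here means that less of the compound is left, a higher number that more of the compound is left:
- compound 1 `O=C(O)c1cc(-c2cccc(COc3ccc4c(c3)CN(C3CCCC3)C4=O)c2)ccc1O`: 98%
- compound 2 `COc1ccc(-c2cccc(COc3ccc4c(c3)CN(C3CCCC3)C4=O)c2)cc1C(=O)O`: 100%
- compound 3 `O=C(O)c1cc(F)cc(-c2cccc(COc3ccc4c(c3)CN(C3CCCC3)C4=O)c2)c1`: 95%

Compound 3, at 95%, stands within the scatter of both other compounds, so the three numbers do not separate. All three sit close to full recovery in this assay.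

Compound 4 `O=C(O)c1ccc(-c2cccc(COc3ccc4c(c3)CN(C3CCCC3)C4=O)c2)c(Cl)c1` keeps the shared core and changes one group, on an aromatic carbon of a six-membered aromatic ring of carbon only, meta to a large group: 4-carboxy-2-chlorophenyl in place of 3-carboxy-5-fluorophenyl (4-carboxy-2-chlorophenyl in place of 3-carboxy-5-fluorophenyl on an aromatic carbon).

The measured steps that bear on this change are those that alter the same aryl group: a number 3 percentage points lower from compound 1 to compound 3 (within the scatter), a number 5 percentage points lower from compound 2 to compound 3 (within the scatter) and a number 2 percentage points higher from compound 1 to compound 2 (within the scatter). All of them are small. Going by the values given here, none of the measured compounds carries the 4-carboxy-2-chlorophenyl group, so the data do not test it directly, and the expectation rests on the series staying flat so far.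

The estimated step is a number 1 percentage points higher from compound 3 to compound 4 (within the scatter), which means no change beyond the scatter is expected in this assay.

For compound 4 the expected value is 96%, with an estimated range of 87% to 100%.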

Compound 4, percent of the compound remaining: 100%
The estimate for compound 4 lay 4 percentage points below the measured number, within the range that was stated.
By their numbers in this assay, from the lowest: compounds 3, 1, 2 and 4 (each within the scatter of the next).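

In this assay the aromatic carbon meta to a large group also accepts 4-carboxy-2-chlorophenyl, the first group shown here with chlorine on this ring, and the read-out gives a number 5 percentage points higher from compound 3 to compound 4 (within the scatter) and no change at the digits printed from compound 2 to compound 4 (within the scatter) as well as a number 2 percentage points higher from compound 1 to compound 4 (within the scatter) with no separation from any earlier compound. The series therefore stays flat across four aryl groups, including one whose name places the carboxy group differently from those of compounds 1, 2 and 3, although this single exchange alters both the halogen and the carboxy placing, so the two cannot be told apart here. The data offer nothing that accounts for this flat behaviour.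

All four compounds shown carry a carboxylic acid on this ring, so it remains open how this assay would read for a methyl ester or an amide at that place, where a group other than the acid would be present. From the compounds shown here alone, it also remains open whether an amine or a longer chain on this ring would leave the read-out as flat as these four compounds do.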